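Swapping propanoyl for propyl on compound 3

A few compounds are considered here, and "the series" means these few. Any claim that something is new, unique, unknown or untested is made for them only; others in the source may bear on it.

- compound 1 `O=C(OCc1ccccc1)c1coc(-c2ccccc2)n1` gives 2.7%
- compound 2 `COc1ccc(CNC(=O)c2c(C)nc3cc(C)ccn23)cc1` gives 33.6%
- compound 3 `CCC(=O)c1ccccc1OC(=O)c1coc(-c2ccccc2)n1` gives 8.7%

All three numbers come from an ADME assay on microsomes from liver (Rattus norvegicus, strain Sprague-Dawley) for metabolic stability, read by LC-MS, with a stated time of 15 min, tested at 20 uM (a higher number here means that more of the compound is left, a lower number that less of the compound is left), and can be compared directly. Compound 1 and compound 3 share the same core, while compound 2 is built differently. Compound 3 at 8.7% lies within the usual scatter of compound 1 at 2.7%, so these two cannot be told apart here. Compound 2 at 33.6% stands beyond the scatter above compound 3.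

The next compound to be tested is compound 4 `CCCc1ccccc1OC(=O)c1coc(-c2ccccc2)n1`, which differs from compound 3 in one place only: propyl in place of propanoyl on an aromatic carbon. The swap is propyl in place of propanoyl, on an aromatic carbon, ortho to a large group.

Among the measured compounds shown here, no measured pair shows a change at this place, so the data give no direct guide to its size. In this assay the expectation is no step beyond the scatter, in either direction. This rests on the two compounds with the shared core: compound 1 gives 2.7% and compound 3 gives 8.7%, close together despite their different groups. The expected result is a number 2.7 percentage points lower from compound 3 to compound 4 (within the scatter). The estimate for compound 4 is 6%, with an expected range from 1% to 16%.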

Compound 4, percent of the compound remaining: 5.4%
For compound 4 the middle estimate is 0.6 percentage points above the measured one; measured number inside the range.
By their numbers in this assay, from the lowest: compounds 1, 4 and 3 (each within the scatter of the next); then compound 2.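

In this assay, among the compounds shown here, this is the first one-place change seen at this position: propyl in place of propanoyl on an aromatic carbon, ortho to a large group, gives a number 3.3 percentage points lower from compound 3 to compound 4 (within the scatter). The step shows that, for this pair, the carbonyl and the one hydrogen-bond acceptor of propanoyl can leave this place without a difference that can be told from the usual variation between repeat measurements, so compound 3 and compound 4 cannot be separated in this test. No measurement here accounts for this outcome.

On these data alone, a single swap at one place says little about the range of groups that this position could hold, so it remains open whether an amine, a carboxylic acid or a longer chain on the same aromatic carbon would give a step beyond the scatter. As far as these compounds go, it also remains open whether a change elsewhere in these two compounds, such as an amide in place of the ester that compound 3 and compound 4 share, would alter the amount of compound left more than any change at this position.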